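This account rests on a few compounds, and the source may have more. Where it says the series, first, only, none or still open, it means among the compounds named here.

Measured compounds in an assay for binding affinity to Indoleamine 2,3-dioxygenase 1 variant C129Y (Homo sapiens), read by spectrophotometry, with a stated time of 30 min; a lower number here means tighter binding, a higher number weaker binding: compound 1 `OC(Cc1ccccc1)c1cccc2[nH]ncc12` gives 66000 nM; compound 2 `C#Cc1cc(C(O)Cc2ccccc2)c2cn[nH]c2c1` gives 94000 nM.

For the measured compounds named here, compound 2 holds the higher of these two numbers, yet the one step, a 1.4-fold higher number from compound 1 to compound 2 (0.15 log units; within the scatter), lies within the scatter. Compound 3 `CCc1cc(C(O)Cc2ccccc2)c2cn[nH]c2c1` differs from compound 2 by ethyl in place of ethynyl on an aromatic carbon. Going by the values given here, no measured step exchanges these two groups; the only step available shows that placing a group at this position barely moved the number. Compound 3 is therefore expected to show no shift beyond the scatter in this assay, a 1.2-fold lower number from compound 2 to compound 3 (0.07 log units; within the scatter). The estimate for compound 3 is 80000 nM, with a range from 30000 nM to 200000 nM.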

Compound 3, dissociation constant: 44000 nM
Compound 3: middle estimate off by 1.8-fold (0.26 log units), on the high side, within the range that was stated.
By their numbers in this assay, from the lowest: compounds 3, 1 and 2 (each within the scatter of the next, the first and the last beyond it).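

In this assay this position now gives its first step beyond the scatter: ethyl in place of ethynyl on the aromatic carbon yields a 2.1-fold lower number from compound 2 to compound 3 (0.33 log units; beyond the scatter) and so the choice of group here can register, if only modestly. Against hydrogen the picture differs, since a 1.5-fold lower number from compound 1 to compound 3 (0.18 log units; within the scatter) stays within the scatter, as does the step to ethynyl, so the two groups separate only from each other and neither separates from compound 1. Nothing available accounts for this difference. The compounds shown leave open whether an amine, a carboxylic acid or a longer chain at this position would move the number beyond the scatter relative to compound 1.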